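A few compounds are considered here, and "the series" means these few. Any claim that something is new, unique, unknown or untested is made for them only; others in the source may bear on it.

Three compounds have been measured in a functional assay on CHO cells for agonist activity at adenosine receptor A1 (Homo sapiens), read by ERK phosphorylation, tested at 3 uM; on this read-out lower numbers stand for a weaker effect and higher numbers for a stronger effect at the one concentration tested:

compound 1 `NNC(=O)c1c(N)sc2c1CCCCCC2`: 48%
compound 2 `Nc1sc2c(c1C(=O)NCc1ccccc1)CCCCCC2`: 48%
compound 3 `Nc1sc2c(c1C(=O)c1cccc(C(F)(F)F)c1)CCCCCC2`: 57%

In this assay compound 1 stands level with compound 2, the two together forming the lowest reading of the three, while compound 3 sits a little higher by an amount that stays within the scatter. Among the compounds with values here, the single measured step, benzyl in place of amino on an amide-type nitrogen, gave no change at the digits printed from compound 1 to compound 2 (within the scatter).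

Compound 4 `Nc1sc2c(c1C(=O)c1ccc(Cl)cc1)CCCCCC2` has not yet been measured. 4-chlorophenyl in place of aminoamino on a carbonyl carbon Here the change sits on the carbonyl carbon itself, not on the nitrogen, so the step from compound 1 to compound 2 bears on it only loosely; it shows that altering the group hanging from the carbonyl left the read-out unchanged. Compound 3 carries an aryl group on the same carbonyl carbon and gives 57%, close to compound 1. A step of similar small size is therefore expected. Compound 4 is expected to give 55%, between 40% and 70%. This estimate means an expected step of a number 7 percentage points higher from compound 1 to compound 4 (within the scatter), within the usual scatter.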

Compound 4, a percentage reported as activity, at one concentration (the size of the read-out at that concentration, not a potency): 56%
For compound 4 the middle estimate is 1 percentage points below the measured one, within the range that was stated.
By their numbers in this assay, from the lowest: compounds 1, 2, 4 and 3 (each within the scatter of the next).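

In this assay, replacing the aminoamino group on the carbonyl carbon with 4-chlorophenyl gives a number 8 percentage points higher from compound 1 to compound 4 (within the scatter). The earlier step changed only a group on the amide-type nitrogen, whereas here that nitrogen is gone and a carbon-only aromatic ring carrying chlorine sits directly on the carbonyl carbon. This position therefore accepts a far larger replacement without any change beyond the scatter, so the nitrogen atoms of the aminoamino group are not needed for a reading of this size at the one concentration tested. No measurement shown here explains why the reading holds.

The compounds shown leave open whether a group without an aromatic ring, such as a methyl or a longer alkyl chain, would be accepted on this carbonyl carbon. As far as these compounds go, because each compound has a reading at one concentration only, their potencies also remain open.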